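The compounds below may be only part of what the source reports. "The series", "measured", "known", "first", "only" and "open" are said of these compounds alone.

Measured compounds in a functional assay on NCI-H460 cells (Homo sapiens) for antiproliferative activity, read by MTT assay; a higher number here means a weaker inhibitor, a lower number a stronger inhibitor:
compound 1, `N#Cc1ncn(Cc2ccccc2Cl)c1/N=C/c1ccc(O)cc1`, gives > 40000 nM, which is a limit of the assay and not a number.
compound 2, `COc1cc(/C=N/c2c(C#N)ncn2Cc2ccccc2Cl)ccc1O`, gives "not determined" (no result reported).
compound 3, `N#Cc1ncn(Cc2ccccc2Cl)c1/N=C/c1ccccc1[N+](=O)[O-]`, gives "not determined" (no result reported).

Compound 1 stands at the limit of > 40000 nM in this assay, at which 1 of the 3 values shown sits, so for it only a limit is known, no single number. For compound 2 and compound 3 no result at all is reported in this assay. For the measured compounds named here, none of the three measured compounds therefore provides a number, and no step between measured compounds can be read from these data.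

Compound 4, `N#Cc1ncn(Cc2ccccc2Cl)c1/N=C/c1ccc(Cl)cc1`, is the compound still to be measured. It differs from compound 1 in one place: chloro in place of hydroxy on an aromatic carbon. Because compound 1 sits at the limit of > 40000 nM in this assay, at which 1 of the 3 values shown sits, the starting point of this step is itself only a limit. Going by the values given here, with no measured step to lean on, the exchange of one atom on the ring is expected to shift the value in this assay by no more than the usual scatter, in no particular direction. Compound 4 is therefore expected to give about 40000 nM, within 10000 nM to 160000 nM, in this assay. The expected step of a number no higher from compound 1 to compound 4 (the limit leaves the size open) is estimated to be small, none beyond the scatter, and a limit rather than a number is the likelier outcome.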

Compound 4, half-maximal inhibitory concentration: 28100 nM
Compound 4: the middle estimate sits 1.4-fold (0.15 log units) above what was measured; the measured number falls inside the stated range.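

In this assay, compound 4 gives 28100 nM, the first single number among these compounds, so the 4-chlorophenyl version of the shared core can be placed on the scale, while the 4-hydroxyphenyl version cannot. Compound 1 gives > 40000 nM, which is a limit of the assay and not a number. The exchange of hydroxy for chloro on the ring gives an at least 1.4-fold lower number from compound 1 to compound 4 (0.15 log units; that floor lies within the scatter), so the data show a lower number but do not establish a real gain in strength, and the true size of the step stays open because one end of it is only a limit: the limit of > 40000 nM in this assay, at which 1 of the 4 values shown sits.

For the compounds shown here, compound 2 and compound 3 have no reported result, so no steps to them can be read. The compounds shown leave open how an amine, a carboxylic acid or a bromo group would read in this same place on the ring, and whether any exchange there could move the value clearly beyond the scatter.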